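Furan-2-yl in place of phenyl: outlook for compound 4

This account rests on a few compounds, and the source may have more. Where it says the series, first, only, none or still open, it means among the compounds named here.

Three compounds of the series have been run in an ADME assay on L6 cells (Rattus norvegicus) for cytotoxicity, read by resazurin assay, with a stated time of 72 h; on this read-out higher numbers stand for weaker inhibition and lower numbers for stronger inhibition. Compound 1 `CCOc1cc(/C=N/N=C(\N)CC(O)c2cccc3ccccc23)ccc1O` gives 4200 nM, compound 2 `N/C(CC(O)c1cccc2ccccc12)=N\N=C\c1ccccc1` gives 17000 nM, and compound 3 `N/C(CC(O)c1ccc2ccccc2c1)=N\N=C\c1ccc(F)cc1F` gives 93000 nM. Compound 2 thus sits second of the three: compound 1 lies lower and compound 3 higher, and both gaps exceed the usual scatter. Among the compounds with values here, no pair differing in a single place has been measured, so no step size is available. Compound 4 `N/C(CC(O)c1cccc2ccccc12)=N\N=C\c1ccco1` differs from compound 2 only by furan-2-yl in place of phenyl on a carbon with a double bond to nitrogen. With nothing to anchor the change, the step is expected to be small, in no firm direction, and most likely within the scatter; the expected step is a 1.2-fold higher number from compound 2 to compound 4 (0.07 log units; within the scatter). For compound 4 the estimate in this assay is 20000 nM, with a range from 6000 nM to 60000 nM.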

Compound 4, half-maximal inhibitory concentration: 145000 nM
The estimate for compound 4 lay 7.3-fold (0.86 log units) below the measured number; the measured number lies above the stated range.
By their numbers in this assay, from the lowest: compound 1; then compound 2; then compounds 3 and 4 (each within the scatter of the next).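

In this assay, the group on a carbon with a double bond to nitrogen is shown to matter: furan-2-yl in place of phenyl gives an 8.5-fold higher number from compound 2 to compound 4 (0.93 log units; beyond the scatter) and thus weaker inhibition, beyond the scatter. Within the data shown here, this is the only single-place step, and it shows that this read-out can respond to this one exchange alone. No available evidence bears on the reason for this step. On these data alone, whether thiophen-2-yl or pyridin-2-yl at this place would track furan-2-yl or phenyl remains open. Also open, as far as these compounds go, is whether the same exchange would give a similar step on the core of compound 3.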